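The source may hold more compounds than are shown below. What is called first, only, known or untested is meant among the compounds shown, and "the series" means these compounds.

The compounds share one core and differ in two places: in the substituent on the pendant aromatic ring and in the pyrazole. Compound 1 `COc1ccc(Cn2nc(Nc3cc(C)[nH]n3)c3ccccc3c2=O)cc1` carries a methoxy group there together with a methylpyrazole, and in a functional assay on HCT-116 cells (Homo sapiens) for cytotoxicity, read by CellTiter-Glo, with a stated time of 5 days (on this read-out higher numbers stand for weaker inhibition and lower numbers for stronger inhibition), compound 1 gives 1200 nM. Compound 2 `Cc1cc(Nc2nn(Cc3ccc(S(C)(=O)=O)cc3)c(=O)c3ccccc23)n[nH]1` differs only by methylsulfonyl in place of methoxy on an aromatic carbon, and in this assay compound 2 gives 1700 nM; the step of a 1.4-fold higher number from compound 1 to compound 2 (0.15 log units; within the scatter) stays within the scatter. Compound 3 `CC(=O)Nc1ccc(Cn2nc(Nc3cc[nH]n3)c3ccccc3c2=O)cc1` carries an acetamido group and an unmethylated pyrazole. In this assay compound 3 gives > 30000 nM, which is a limit of the assay and not a number, as the limit of > 30000 nM in this assay, at which 1 of the 3 values shown sits, records. Compound 4 `CC(=O)Nc1ccc(Cn2nc(Nc3cc(C)[nH]n3)c3ccccc3c2=O)cc1` is compound 3 with methyl in place of hydrogen on an aromatic carbon. Among the measured compounds shown here, no measured step covers this change; the only measured step, a 1.4-fold higher number from compound 1 to compound 2 (0.15 log units; within the scatter), concerns a different substituent and is small. What the data show is that both measured numbers, for compound 1 and compound 2, belong to compounds bearing the methylpyrazole, while the single limit belongs to the compound without it. Compound 4 is therefore expected to leave the limit for a measurable number, estimated as 4000 nM within 1200 nM to 30000 nM. The expected step is an at least 7.5-fold lower number from compound 3 to compound 4 (0.87 log units; beyond the scatter), with a real chance that compound 4 still reaches only the limit.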

Compound 4, half-maximal inhibitory concentration: 4200 nM
For compound 4 the middle estimate is 1.1-fold (0.02 log units) below the measured one, within the range that was stated.
By their numbers in this assay, from the lowest: compounds 1 and 2 (each within the scatter of the next); then compound 4. At a limit, above all of these: compound 3.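

With the acetamido group held fixed, the change from 1H-pyrazol-3-yl to 5-methyl-1H-pyrazol-3-yl gives an at least 7.1-fold lower number from compound 3 to compound 4 (0.85 log units; beyond the scatter), so a single methyl on this aromatic carbon is the first change in the series shown to move the number beyond the scatter. Compound 3 stands at a limit of the assay and not at a number, so this step gives only a lower bound on the size of the change: the limit of > 30000 nM in this assay, at which 1 of the 4 values shown sits. With the methylpyrazole kept, the substituent on the pendant aromatic ring also proves to matter modestly, for acetamido gives a 2.5-fold higher number from compound 2 to compound 4 (0.39 log units; beyond the scatter) and a 3.5-fold higher number from compound 1 to compound 4 (0.54 log units; beyond the scatter), whereas the earlier exchange of methoxy for methylsulfonyl stayed within the scatter.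

From the compounds shown here alone, the unmethylated pyrazole appears only in compound 3, so it remains open whether the methyl would matter as much alongside methoxy or methylsulfonyl on the pendant ring. Going by these compounds, it also remains open whether an ethyl, a trifluoromethyl or an amine on the same aromatic carbon of the pyrazole would hold, extend or lose what the methyl achieves.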